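The compounds below may be only part of what the source reports. "The series", "measured", "known", "first", "only" and "open" are said of these compounds alone.

Compound 1 `CC(NC(=O)CCc1ccc(NC(=O)Nc2ccc(Cl)c(C(F)(F)F)c2)cc1)c1ccccc1` gives > 50000 nM in a functional assay on KETR3 cells (Homo sapiens) for inhibition, read by MTT assay, with a stated time of 120 h (a lower number here means a stronger inhibitor, a higher number a weaker inhibitor), which is a limit of the assay and not a number.
Compound 2 `CC(NC(=O)c1ccc(-c2ccc(NC(=O)Nc3cc(C(F)(F)F)ccc3Cl)cc2)cc1)c1ccccc1` gives 16800 nM in this assay.
Compound 3 `CC1CN(C(=O)CCc2ccc(NC(=O)Nc3ccc(Cl)c(C(F)(F)F)c3)cc2)CC(C)O1` gives > 50000 nM in this assay, again a limit and not a number.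

Compound 1 and compound 3 differ in one place: 2,6-dimethylmorpholin-4-yl in place of (1-phenylethyl)amino on a carbonyl carbon. The step that the two limits leave unreadable from compound 1 to compound 3 cannot be read, because both values sit at the limit of > 50000 nM in this assay, at which 2 of the 3 values shown sit. Compound 2 carries a different core; how its core differs from that of compound 1 is not broken down here. Compound 4 `CC1CN(C(=O)c2ccc(-c3ccc(NC(=O)Nc4cc(C(F)(F)F)ccc4Cl)cc3)cc2)CC(C)O1` has not yet been measured and differs from compound 2 by the same kind of change: 2,6-dimethylmorpholin-4-yl in place of (1-phenylethyl)amino on a carbonyl carbon. Around the place the two cases differ: in compound 1 the carbonyl carbon's other neighbour is a saturated chain carbon, in compound 2 it is an aromatic carbon. Compound 2 is itself only a weak inhibitor, so a step of a 1.8-fold higher number from compound 2 to compound 4 (0.25 log units; within the scatter) is expected in this assay, with a real chance that only a limit is returned. For compound 4 the estimate is 30000 nM, spanning 10000 nM to 60000 nM.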

Compound 4, half-maximal inhibitory concentration: > 50000 nM
Compound 4: a limit, no number; the forecaster's own chance of this, stated with the estimate: 50%; at least 1.6-fold (0.22 log units) between middle value and limit.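

On the core of compound 2, putting 2,6-dimethylmorpholin-4-yl in place of (1-phenylethyl)amino on the carbonyl carbon gives an at least 2.9-fold higher number from compound 2 to compound 4 (0.47 log units; beyond the scatter) in this assay, so on this core the change leaves a weaker inhibitor. For compound 4, > 50000 nM is a limit of the assay and not a number, so this step has a lower bound but no exact size. The same change on the core of compound 1 cannot be read, so the data do not show whether the step carries over from one core to the other, because compound 1 and compound 3 both give only a limit: the limit of > 50000 nM in this assay, at which 3 of the 4 values shown sit.

From the compounds shown here alone, it remains open whether the two methyl groups of the ring matter, which a plain morpholin-4-yl on the same carbonyl carbon would help to test. Going by these compounds, it is also open whether a smaller dimethylamino group there would give a number on either core.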